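The compounds below may be only part of what the source reports. "The series", "measured", "known", "first", "only" and "open" are said of these compounds alone.

Three compounds of one shared core were measured in a physicochemical assay for solubility, at pH 6.8; a higher number here means a more soluble compound, a lower number a less soluble compound. Compound 1, `Cc1cn2c(N3CC[C@H](N(C)C)C3)c(-c3ccccc3)c(C)c(C#N)c2n1`, gave 356 ug/mL. Compound 2, `CCN(CC)CCNc1c(-c2ccccc2)c(C)c(C#N)c2nc(C(C)(C)C)nn12`, gave 2 ug/mL. Compound 3, `CCCCc1nc2c(C#N)c(C)c(-c3ccccc3)c(N3CC[C@H](N(C)C)C3)n2n1`, gave 33 ug/mL. On these three numbers compound 3 stands second highest: its nearest neighbour is compound 1, which lies higher by a step beyond the scatter, and its furthest is compound 2, which lies lower by a step also beyond the scatter.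

The account now turns to compound 4, `Cc1c(-c2ccccc2)c(N2CC[C@H](N(C)C)C2)n2nc(C3CC3)nc2c1C#N`, which has not yet been measured in this assay. It differs from compound 3 in one place: cyclopropyl in place of butyl on an aromatic carbon. Among the measured compounds shown here, no pair of measured compounds differs only in this way, so no measured step can be borrowed; the expectation rests on the change itself. The step of a 2.7-fold higher number from compound 3 to compound 4 (0.44 log units; beyond the scatter) is expected to be a modest rise, of a size that stays close to the scatter rather than matching the gaps between compounds 1, 3 and 2. For compound 4 the estimate in this assay is 90 ug/mL, with a range from 30 ug/mL to 270 ug/mL.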

Compound 4, solubility: 57 ug/mL
Beside the measured number, compound 4's estimate is 1.6-fold (0.20 log units) above it; the measured number falls inside the stated range.
By their numbers in this assay, from the lowest: compound 2; then compounds 3 and 4 (each within the scatter of the next); then compound 1.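

In this assay, cyclopropyl in place of butyl on this aromatic carbon gives a 1.7-fold higher number from compound 3 to compound 4 (0.24 log units; within the scatter), and this is the first pair among these compounds that differs in one place only. At this position, between two ring nitrogen atoms, the open butyl chain and the three-membered ring of carbon only therefore give numbers within the scatter of each other, even though the ring brings one heavy atom fewer. Nothing at hand bears on the reason for this result.

Still open, from the compounds shown here alone, is whether the same holds for groups of another kind on this carbon, such as an amine, a carboxylic acid or a chain longer than butyl. Among the compounds shown here, it is also open whether cyclopropyl and butyl would again read alike with the open-chain amine of compound 2 in place of the one in compound 3.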